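Swapping the Benzyl Group on a Sulfonamide Amine

The compounds below may be only part of what the source reports. "The series", "measured", "known", "first", "only" and "open" are said of these compounds alone.

Compound 1, `O=S(=O)(NCCCNCC1COc2ccccc2O1)c1cc(C(F)(F)F)cc(C(F)(F)F)c1`, gives 3400 nM in a functional assay on PANC-1 cells (Homo sapiens) for inhibition, read by MTT assay, with a stated time of 72 h; a higher number here means a weaker inhibitor of growth, a lower number a stronger inhibitor of growth.
Compound 2, `COc1ccc(CNCCCNS(=O)(=O)c2cc(C(F)(F)F)cc(C(F)(F)F)c2)cc1`, gives 11000 nM in this assay.

Among the measured compounds shown here, compound 2 stands at the higher of the two numbers so far, the weaker growth inhibitor; the only measured step, a 3.2-fold higher number from compound 1 to compound 2 (0.51 log units; beyond the scatter), separates it from compound 1. Compound 3 is `O=S(=O)(NCCCNCc1cccc(Cl)c1)c1cc(C(F)(F)F)cc(C(F)(F)F)c1`. It differs from compound 2 by 3-chlorophenyl in place of 4-methoxyphenyl on a saturated chain carbon bound to an amine nitrogen. That single measured step touches the same place on the chain but exchanges a different pair of groups, so it bears on this change only loosely: it shows that groups at this place shift the number by a modest amount. With nothing closer to go on, a modest step in either direction is expected, probably not far beyond the scatter, as a 1.7-fold lower number from compound 2 to compound 3 (0.23 log units; within the scatter). Compound 3 is therefore estimated at 6500 nM, within 2500 nM to 17000 nM.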

Compound 3, concentration for 50% growth inhibition: 12000 nM
Compound 3: middle estimate off by 1.8-fold (0.27 log units), on the low side; low and high end bracket the measured number.
By their numbers in this assay, from the lowest: compound 1; then compounds 2 and 3 (each within the scatter of the next).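

In this assay, trading 4-methoxyphenyl for 3-chlorophenyl at this place on the chain gives a 1.1-fold higher number from compound 2 to compound 3 (0.04 log units; within the scatter), so this particular exchange of ring substituents, oxygen-bearing for chlorine-bearing, leaves the number unmoved within the scatter. The 2,3-dihydro-1,4-benzodioxin-2-yl group also holds its advantage over this second aromatic group, with a 3.5-fold higher number from compound 1 to compound 3 (0.55 log units; beyond the scatter), so the gap first seen with compound 2 is not confined to 4-methoxyphenyl. No measurement is available here that would explain either result.

The compounds shown leave open whether a plain unsubstituted benzyl group, or a ring carrying an amine or a carboxylic acid, would sit with compound 2 and compound 3 or nearer compound 1. They also leave open whether the lower number of compound 1 needs the whole 2,3-dihydro-1,4-benzodioxin-2-yl group or would survive with a simple phenoxymethyl group instead.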